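The source may hold more compounds than are shown below. What is called first, only, known or untested is meant among the compounds shown, and "the series" means these compounds.

Working notes on a short series built on one shared core, the three measured members differing only in the group on a carbonyl carbon. Compound 1 `CC1(C)S[C@@H]2/C(=C\C(=O)c3ccco3)C(=O)N2[C@H]1C(=O)OC(c1ccccc1)c1ccccc1` gives 61500 nM in a functional assay on NCI-H1299 cells (Homo sapiens) for cytotoxicity, read by MTT assay, with a stated time of 48 h; on this read-out higher numbers stand for weaker inhibition and lower numbers for stronger inhibition. Compound 2 `CCOC(=O)/C=C1/C(=O)N2[C@@H]1SC(C)(C)[C@@H]2C(=O)OC(c1ccccc1)c1ccccc1` gives 15000 nM in this assay, and compound 3 `CC(=O)/C=C1/C(=O)N2[C@@H]1SC(C)(C)[C@@H]2C(=O)OC(c1ccccc1)c1ccccc1` gives 24200 nM. Compound 3 therefore stands second highest of the three numbers, close to compound 2 through the step of a 1.6-fold higher number from compound 2 to compound 3 (0.21 log units; within the scatter), and set apart from compound 1 through the step of a 2.5-fold lower number from compound 1 to compound 3 (0.41 log units; beyond the scatter). Compound 4 `CC1(C)S[C@@H]2/C(=C\C(=O)c3ccc(F)cc3)C(=O)N2[C@H]1C(=O)OC(c1ccccc1)c1ccccc1` is not yet measured and differs from compound 3 in one place: 4-fluorophenyl in place of methyl on a carbonyl carbon. The change runs opposite to the one behind a 2.5-fold lower number from compound 1 to compound 3 (0.41 log units; beyond the scatter), an aromatic ring replacing methyl on the carbonyl carbon, whereas a 1.6-fold higher number from compound 2 to compound 3 (0.21 log units; within the scatter) at the same place stayed within the scatter. Compound 4 is thus expected to return a higher number than compound 3 in this assay, about the size of a 2.5-fold lower number from compound 1 to compound 3 (0.41 log units; beyond the scatter) reversed. The expected step is a 2.1-fold higher number from compound 3 to compound 4 (0.32 log units; beyond the scatter). Compound 4 is estimated at 50000 nM, with a range from 20000 nM to 120000 nM.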

Compound 4, half-maximal inhibitory concentration: 25200 nM
Compound 4: middle estimate off by 2.0-fold (0.30 log units), on the high side; the measured number falls inside the stated range.
By their numbers in this assay, from the lowest: compounds 2, 3 and 4 (each within the scatter of the next); then compound 1.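

In this assay, replacing methyl with 4-fluorophenyl on this carbonyl carbon gives a 1.0-fold higher number from compound 3 to compound 4 (0.02 log units; within the scatter), and replacing ethoxy with the same group gives a 1.7-fold higher number from compound 2 to compound 4 (0.23 log units; within the scatter). An aromatic ring at this place therefore does not by itself go with a higher number: furan-2-yl stands apart from 4-fluorophenyl, with a 2.4-fold lower number from compound 1 to compound 4 (0.39 log units; beyond the scatter), so the gap seen earlier cannot be assigned to aromatic rings as a class. Among the four compounds, methyl, ethoxy and 4-fluorophenyl cannot be ranked at this position. Nothing at hand accounts for the different reading of furan-2-yl and 4-fluorophenyl. The compounds shown leave open how a plain phenyl or a thiophen-2-yl would read here, which would test whether the fluorine or the furan oxygen matters, and how an amine or a carboxylic acid on this carbonyl carbon would read.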